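Dimethylamino for Fluoro in a Quinoline-free Urea Series

The source may report more compounds than this note shows. Statements on the series, on what has been measured and on what is new or still open speak of the compounds shown alone.

Three ureas sharing one core have been measured in an ADME assay for permeability, using PAMPA, at pH 7.4; on this read-out higher numbers stand for higher permeability and lower numbers for lower permeability. Compound 1 `COc1ccc(NC(=O)Nc2cc(C)nc3ccccc23)cc1` gives 787 10^-6 cm/s. Compound 2 `Cc1cc(NC(=O)Nc2cccc(Cl)c2)c2ccccc2n1` gives 566 10^-6 cm/s in this assay . Compound 3 `Cc1cc(NC(=O)Nc2ccc(F)cc2)c2ccccc2n1` gives 801 10^-6 cm/s in this assay . Compound 3 stands with the other two: the step of a 1.0-fold higher number from compound 1 to compound 3 (0.01 log units; within the scatter) and the step of a 1.4-fold higher number from compound 2 to compound 3 (0.15 log units; within the scatter) both fall within the scatter, so the three numbers cannot be told apart.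

The next compound, compound 4 `Cc1cc(NC(=O)Nc2ccc(N(C)C)cc2)c2ccccc2n1`, differs from compound 3 in one place: dimethylamino in place of fluoro on an aromatic carbon. For the measured compounds named here, no measured pair shows this particular change. The two steps that exist, from compound 1 to compound 3 and from compound 2 to compound 3, each swap one small group on the phenyl ring of the urea for another and both stay within the scatter. On that basis, a change on the same ring is expected to leave compound 4 near compound 3, with the step of a 1.3-fold lower number from compound 3 to compound 4 (0.11 log units; within the scatter) expected to stay within the scatter. Compound 4 is therefore estimated to give 620 10^-6 cm/s in this assay , within the range 310 10^-6 cm/s to 950 10^-6 cm/s.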

Compound 4, apparent permeability: 2 10^-6 cm/s
Estimate against measurement, compound 4: 310-fold (2.49 log units) above, and the stated range ends above it.
By their numbers in this assay, from the lowest: compound 4; then compounds 2, 1 and 3 (each within the scatter of the next).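

In this assay, this aromatic carbon, para to a large group, turns out to be far from indifferent to what sits on it: a 400-fold lower number from compound 3 to compound 4 (2.60 log units; beyond the scatter) and a 390-fold lower number from compound 1 to compound 4 (2.59 log units; beyond the scatter) are both large, whereas a 1.0-fold higher number from compound 1 to compound 3 (0.01 log units; within the scatter) stays within the scatter. The earlier calm at this place therefore holds for fluoro and methoxy only, and it cannot be carried over to every small group, since dimethylamino, with 3 heavy atoms and 1 hydrogen-bond acceptor against 1 heavy atom and 0 acceptors for fluoro, gives a very different number. Nothing available here accounts for a step of this size, so it stands as an observation without a known cause.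

Going by these compounds, what remains open is whether the step belongs to the nitrogen itself or to the two methyl groups on it, a question that a simple amine or a methylamino group on the same carbon would help to settle. On these data alone, it is also open whether a longer chain such as diethylamino, or the all-carbon isopropyl group, would give a number near compound 4 or near compound 3.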